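From an aryl urea to a cyclohexyl carbamate on a shared core

The source may report more compounds than this note shows. Statements on the series, on what has been measured and on what is new or still open speak of the compounds shown alone.

Compound 1, `O=C(CC1CCCCCC1)N1CCC(c2nc(-c3ccc4ccccc4n3)no2)CC1`: 840 nM
Compound 2, `COc1ccccc1N(C)C(=O)N1CCC(c2nc(-c3ccc4ccccc4n3)no2)CC1`: 3100 nM

Both compounds were tested in a functional assay on Shh Light II cells (Mus musculus) for inhibition, read by a luciferase reporter; a lower number here means a stronger inhibitor, a higher number a weaker inhibitor. Compound 2 stands at the higher of the two numbers, the step of a 3.7-fold higher number from compound 1 to compound 2 (0.57 log units; beyond the scatter) being modest but beyond the scatter, while compound 1 gives the lower number.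

Compound 3, `O=C(OC1CCCCC1)N1CCC(c2nc(-c3ccc4ccccc4n3)no2)CC1`, has not yet been measured in this assay. It differs from compound 2 in a single place: cyclohexyloxy in place of (2-methoxyphenyl)(methyl)amino on a carbonyl carbon. For the measured compounds named here, the only measured step that bears on this change is a 3.7-fold higher number from compound 1 to compound 2 (0.57 log units; beyond the scatter), in which a group built on a non-aromatic carbon ring on the carbonyl carbon gave the lower number and the (2-methoxyphenyl)(methyl)amino group gave the higher one. Cyclohexyloxy again brings a six-membered non-aromatic ring of carbon only to the same carbonyl carbon. Because in a 3.7-fold higher number from compound 1 to compound 2 (0.57 log units; beyond the scatter) the non-aromatic ring went with the lower number, compound 3 is expected to move downward by a 2.8-fold lower number from compound 2 to compound 3 (0.45 log units; beyond the scatter). The estimate for compound 3 in this assay is 1100 nM, with a range from 400 nM to 3200 nM.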

Compound 3, half-maximal inhibitory concentration: 580 nM
The estimate for compound 3 lay 1.9-fold (0.28 log units) above the measured number; the range from low to high includes it.
By their numbers in this assay, from the lowest: compounds 3 and 1 (each within the scatter of the next); then compound 2.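

In this assay, cyclohexyloxy in place of (2-methoxyphenyl)(methyl)amino on the carbonyl carbon gives a 5.3-fold lower number from compound 2 to compound 3 (0.73 log units; beyond the scatter), so a second group with a non-aromatic carbon ring now stands on the low side of the aromatic group, and the earlier contrast no longer rests on compound 1 alone. The two non-aromatic groups, however, cannot be told apart: a 1.4-fold lower number from compound 1 to compound 3 (0.16 log units; within the scatter), which means that exchanging cycloheptylmethyl for cyclohexyloxy, with a different ring size and an oxygen linking the ring to the carbonyl carbon, leaves no readable change at this position. No measurement shown here offers an explanation for these differences.

Compound 2 differs from compound 1 and compound 3 both in its aromatic ring and in its methyl-bearing nitrogen on the carbonyl carbon, so the compounds shown leave open which of these features goes with its higher number. A phenoxy group or a cyclohexylamino group on the same carbonyl carbon would separate the two, and a cyclopentyloxy group would test whether ring size matters at all.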